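The compounds below may be only part of what the source reports. "The series", "measured", "known", "first", "only" and "open" are said of these compounds alone.

Measured so far:
compound 1 `Cc1nc2c(OCc3ccccc3)cccn2c1C(N)=O`, 42%
compound 2 `Cc1nc2c(OCc3ccccc3)cccn2c1C#N`, 25%
compound 3 `COCc1c(C)nc2c(OCc3ccccc3)cccn12`, 99%

In a functional assay on the whole organism with Rattus norvegicus as the target, with a stated time of 4 h, at a dose of 40 mg/kg by the intraperitoneal route (a higher number here means more inhibition at the dose given (going by the name of the read-out), a lower number less inhibition), compound 1 stands second highest of the three; compound 2 lies a number 17 percentage points lower from compound 1 to compound 2 (beyond the scatter) and compound 3 lies a number 57 percentage points higher from compound 1 to compound 3 (beyond the scatter). Compound 4 `Cc1nc2c(OCc3ccccc3)cccn2c1Br` differs from compound 1 by bromo in place of carbamoyl on an aromatic carbon. Two measured steps leave the same carbamoyl: the modest drop a number 17 percentage points lower from compound 1 to compound 2 (beyond the scatter) and the large rise a number 57 percentage points higher from compound 1 to compound 3 (beyond the scatter). They point in opposite directions, so the bromo change is hard to read from them. Replacing the carbamoyl has moved this assay beyond the scatter both ways, so a step of some size is expected for compound 4, but its direction is uncertain, and the estimate is kept near compound 1: compound 4 is expected to give 50%, between 20% and 85%, a step of a number 8 percentage points higher from compound 1 to compound 4 (within the scatter).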

Compound 4, a percentage reported as inhibition, in the whole organism at one dose (the size of the read-out at that dose, not a potency): 26%
Compound 4: middle estimate off by 24 percentage points, on the high side; the range from low to high includes it.
By their numbers in this assay, from the lowest: compounds 2 and 4 (each within the scatter of the next); then compound 1; then compound 3.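

In this assay, bromo on this aromatic carbon brings a number 16 percentage points lower from compound 1 to compound 4 (beyond the scatter), so a replacement of a single heavy atom also lowers the number, and the step of a number 1 percentage points higher from compound 2 to compound 4 (within the scatter) places the bromo and cyano compounds level. Among the replacements shown, methoxymethyl alone raises the number, and the step of a number 73 percentage points lower from compound 3 to compound 4 (beyond the scatter) sets it far apart from bromo. No measurement here explains these differences. On these data alone, whether an aminomethyl, a carboxylic acid or a longer ether chain such as ethoxymethyl at this position would behave like methoxymethyl or like bromo remains open.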